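Predicting a Methoxypyridinyl Replacement for a Methoxyphenyl Group

The source may report more compounds than this note shows. Statements on the series, on what has been measured and on what is new or still open speak of the compounds shown alone.

Three measured compounds share one core and differ only in the aromatic group attached to it. Compound 1 `COc1ccccc1-c1cnc(C(=O)CCCCCCc2ccccc2)o1` carries a 2-methoxyphenyl group there; in an assay (Rattus norvegicus) for inhibition of Fatty-acid amide hydrolase 1 (Homo sapiens) (on this read-out higher numbers stand for weaker inhibition and lower numbers for stronger inhibition), compound 1 gives 400 nM, the highest of the three numbers and thus the weakest inhibitor among them. Compound 2 `O=C(CCCCCCc1ccccc1)c1ncc(-c2cccc(O)c2)o1` bears a 3-hydroxyphenyl group instead, and in this assay compound 2 gives 50 nM. Compound 3 `N#Cc1ccc(-c2cnc(C(=O)CCCCCCc3ccccc3)o2)cc1` bears a 4-cyanophenyl group, and in this assay compound 3 gives 40 nM. Both replacements improve on compound 1: an 8.0-fold lower number from compound 1 to compound 2 (0.90 log units; beyond the scatter) and a 10-fold lower number from compound 1 to compound 3 (1.00 log units; beyond the scatter), while a 1.3-fold lower number from compound 2 to compound 3 (0.10 log units; within the scatter).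

Compound 4 `COc1ccnc(-c2cnc(C(=O)CCCCCCc3ccccc3)o2)c1` has not yet been measured. It differs from compound 1 in one place: 4-methoxypyridin-2-yl in place of 2-methoxyphenyl on an aromatic carbon. Both measured steps away from 2-methoxyphenyl bear on this change, and both lowered the number by roughly the same amount. Neither of them, however, placed a hetero atom in the six-membered ring, and neither kept a methoxy group, so the new group lies somewhat outside what has been tested directly. On this basis compound 4 is expected to show a step of a 10-fold lower number from compound 1 to compound 4 (1.00 log units; beyond the scatter), so its estimated value is 40 nM, with a range from 8 nM to 200 nM.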

Compound 4, inhibition constant: 0.8 nM
Compound 4: the middle estimate sits 50-fold (1.70 log units) above what was measured, and the stated range ends above it.
By their numbers in this assay, from the lowest: compound 4; then compounds 3 and 2 (each within the scatter of the next); then compound 1.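

Placing 4-methoxypyridin-2-yl on this aromatic carbon, next to the ring oxygen of the shared core, gives in this assay a 500-fold lower number from compound 1 to compound 4 (2.70 log units; beyond the scatter), a far larger step than either earlier replacement of the 2-methoxyphenyl group produced. The new group also clearly outperforms the two better earlier groups, with a 50-fold lower number from compound 3 to compound 4 (1.70 log units; beyond the scatter) and a 63-fold lower number from compound 2 to compound 4 (1.80 log units; beyond the scatter), so this position can support much stronger inhibition than compounds 2 and 3 had suggested, and compound 4 is the strongest inhibitor of the four. The entering and leaving groups have the same number of heavy atoms, yet they differ in two ways at once, with a ring nitrogen present and the methoxy group placed differently, and nothing available here explains the size of the gain.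

On these data alone, it remains open which of those two differences matters, and a plain pyridin-2-yl group and a 4-methoxyphenyl group at this position would help to separate them. As far as these compounds go, it is also open whether larger ethoxy or smaller hydroxy groups on the pyridine ring would keep the gain seen with the methoxy group.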